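Bromo to Chloro at the Edge of Detection

The source may hold more compounds than are shown below. What is called first, only, known or untested is meant among the compounds shown, and "the series" means these compounds.

Compound 1: `Nc1nc(=O)n([C@@H]2CS[C@@H](CO)O2)cc1Br` — > 100000 nM
Compound 2: `Nc1nc(Cl)c2ncn([C@@H]3CS[C@@H](CO)O3)c2n1` — > 100000 nM

Of the compounds shown here, two have been measured in a functional assay on Vero cells (Chlorocebus sabaeus) for inhibition; a higher number here means a weaker inhibitor, a lower number a stronger inhibitor. Compound 1, with the structure `Nc1nc(=O)n([C@@H]2CS[C@@H](CO)O2)cc1Br`, gives in this assay a value of > 100000 nM, which is a limit of the assay rather than a number. Compound 2, with the structure `Nc1nc(Cl)c2ncn([C@@H]3CS[C@@H](CO)O3)c2n1`, gives > 100000 nM in this assay, again a limit. For the measured compounds named here, compound 1 therefore stands at the limit of > 100000 nM in this assay, at which 2 of the 2 values shown sit: no measured value in this small set falls inside the measurable range, and no step between measured compounds exists to lean on.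

Compound 3, `Nc1nc(=O)n([C@@H]2CS[C@@H](CO)O2)cc1Cl`, differs from compound 1 in a single respect: chloro in place of bromo on an aromatic carbon. Because compound 1 sits at the limit of > 100000 nM in this assay, at which 2 of the 2 values shown sit, the size of the step to compound 3 in this assay can only be judged loosely, and nothing in the data points toward a move into the measurable range. The step that the limit leaves unreadable from compound 1 to compound 3 is expected to be essentially none, well within the scatter. For compound 3 the estimated value in this assay is 150000 nM, with a range from 50000 nM to 500000 nM, and most likely it will again be reported only as a limit.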

Compound 3, half-maximal inhibitory concentration: 31200 nM
For compound 3 the middle estimate is 4.8-fold (0.68 log units) above the measured one, outside the stated range (below it).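

This carbon, ortho to an amino group on the six-membered aromatic ring, turns out to be responsive: in this assay, placing chloro where bromo stood gives an at least 3.2-fold lower number from compound 1 to compound 3 (0.50 log units; beyond the scatter). Both groups count as a single heavy atom with no hydrogen-bond donors, no hydrogen-bond acceptors and no net charge, so a change this small in those counts is still enough to bring compound 3 to a real number, the first among the compounds shown. That step is only a minimum and its true size stays hidden, because compound 1 has no number of its own: the limit of > 100000 nM in this assay, at which 2 of the 3 values shown sit.

The compounds shown leave open how the value would respond to other groups at this carbon, such as fluoro, iodo, a methyl group or a nitrile, and so whether chloro is a lone good fit or one point on a wider trend. For the compounds shown here, they also leave open whether the same exchange of bromo for chloro would give a step in the same direction on a different core, since only this one pair can be read.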